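A Fluorine Moved Around the Ring: Compound 4 Expected

The source may report more compounds than this note shows. Statements on the series, on what has been measured and on what is new or still open speak of the compounds shown alone.

Of the compounds shown here, three sharing one core have been measured in an ADME assay on HepG2 cells (Homo sapiens) for inhibition, read by resazurin assay, with a stated time of 48 h; on this read-out lower numbers stand for an effect already at smaller amounts and higher numbers for an effect only at larger amounts of compound. Compound 1, `O=C(Nc1ccc2sc(-c3cccc(F)c3F)nc2c1)N1CCCC1`, gives > 50 uM in this assay, which is a limit of the assay rather than a number. Compound 2, `O=C(Nc1ccc2sc(-c3cccc(F)c3)nc2c1)N1CCCC1`, likewise reaches only the limit of > 50 uM. Compound 3, `O=C(Nc1ccc2sc(-c3ccccc3)nc2c1)c1cccs1`, also stands at the limit of > 50 uM. Among the measured compounds shown here, the single step between measured compounds, a step that the two limits leave unreadable from compound 1 to compound 2, cannot be read, both of its ends being limits. On the numbers shown, compound 2 thus stands at the same limit as every other measured compound, and nothing places it higher or lower than them.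

Compound 4, `O=C(Nc1ccc2sc(-c3ccc(F)cc3)nc2c1)N1CCCC1`, has not yet been measured in this assay. Its difference from compound 2 is 4-fluorophenyl in place of 3-fluorophenyl on an aromatic carbon. For the measured compounds named here, no measured step bears directly on this exchange of one fluorophenyl for another, and the one step that exists is unreadable. The expectation rests instead on (the limit of > 50 uM in this assay, at which 3 of the 3 values shown sit). The step that the limit leaves unreadable from compound 2 to compound 4 is expected to be none beyond the scatter. Compound 4 is therefore estimated at 70 uM, within 30 uM to 150 uM, and most likely it will again be reported only as a limit.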

Compound 4, concentration for 90% of the maximal effect: > 50 uM
Compound 4: no number, only a limit; the forecaster's own chance of this, stated with the estimate: 85%; the middle value lies beyond the limit too.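

In this assay compound 4 gives > 50 uM, which is a limit of the assay and not a number. The steps to compound 4 from compound 1 and from compound 2 therefore cannot be read. The compounds shown leave open whether 2,3-difluorophenyl, 3-fluorophenyl and 4-fluorophenyl differ at all on this read-out, and all that can be reported is: the limit of > 50 uM in this assay, at which 4 of the 4 values shown sit.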